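The compounds below may be only part of what the source reports. "The series", "measured", "known", "first", "only" and "open" are said of these compounds alone.

Measured compounds:
compound 1 `COc1ccc(/C=N\NC(=S)NC(C)(C)CCC[C@](C)(O)[C@@H]2CC=C(C)CC2)cc1` — 22100 nM
compound 2 `CC1=CC[C@@H]([C@@](C)(O)CCCC(C)(C)NC(=S)N/N=C\c2ccc(O)cc2)CC1` — 40100 nM

Both compounds were tested in a functional assay on UACC-62 cells (Homo sapiens) for cytotoxicity, read by sulforhodamine B assay; on this read-out lower numbers stand for stronger inhibition of growth and higher numbers for weaker inhibition of growth. Compound 1 gives 22100 nM, and compound 2 gives 40100 nM. Among the measured compounds shown here, the one measured step, a 1.8-fold higher number from compound 1 to compound 2 (0.26 log units; within the scatter), replaces the methyl on the aromatic oxygen with hydrogen. Compound 1 has the lower of the two numbers, but since its gap to compound 2 sits within the scatter, neither compound can be called the stronger one.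

Compound 3 `CC1=CC[C@@H]([C@@](C)(O)CCCC(C)(C)NC(=S)N/N=C\c2ccc([N+](=O)[O-])cc2)CC1` has not yet been measured. It differs from compound 1 by nitro in place of methoxy on an aromatic carbon; cut one bond further out, the change reads 4-methoxyphenyl to 4-nitrophenyl, the group sitting on an aromatic carbon of a six-membered aromatic ring of carbon only, para to a large group. For the measured compounds named here, no measured step involves a nitro group. Going by the values given here, the only step recorded, a 1.8-fold higher number from compound 1 to compound 2 (0.26 log units; within the scatter), alters the same position of the ring and stays within the scatter, so a step of a similar size, in no clear direction, is expected here. The account therefore estimates a step of a 1.1-fold higher number from compound 1 to compound 3 (0.05 log units; within the scatter) for compound 3. Compound 3 is expected to give about 25000 nM, within a range of 8000 nM to 80000 nM.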

Compound 3, concentration for total growth inhibition: 62200 nM
Beside the measured number, compound 3's estimate is 2.5-fold (0.40 log units) below it; low and high end bracket the measured number.
By their numbers in this assay, from the lowest: compounds 1, 2 and 3 (each within the scatter of the next, the first and the last beyond it).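

In this assay, the change from 4-methoxyphenyl to 4-nitrophenyl gives a 2.8-fold higher number from compound 1 to compound 3 (0.45 log units; beyond the scatter), a modest step and the first at this place on the ring to go beyond the scatter, so the group here can shift the read-out, in this case towards weaker inhibition of growth. The picture is narrower than a simple ranking, however: nitro in place of hydroxy gives a 1.6-fold higher number from compound 2 to compound 3 (0.19 log units; within the scatter), which leaves compound 2 and compound 3 indistinguishable, just as compound 1 and compound 2 are, so only the methoxy and nitro compounds stand apart. No information is available that bears on this result.

The compounds shown leave open what an amine, a chlorine atom or a longer ether such as ethoxy would give at this place, and so whether the methoxy group of compound 1 lies near the end of a wider range or in the middle of it. They also leave open whether the step from methoxy to nitro would be of similar size on another core, since all three compounds share the same one.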